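Chain ether swap on the aminoquinoline series

A few compounds are considered here, and "the series" means these few. Any claim that something is new, unique, unknown or untested is made for them only; others in the source may bear on it.

Measured so far:
compound 1 `CCOCCOc1cccc2ccc(N)nc12` gives > 2000 nM
compound 2 `CCCCCOc1cccc2ccc(N)nc12` gives 580 nM

In an assay on cells with melanin-concentrating hormone receptor 1 (Homo sapiens) as the target, read by radioligand binding (on this read-out lower numbers stand for stronger inhibition and higher numbers for weaker inhibition), compound 1 gives > 2000 nM; this is a limit of the assay, not a number (the limit of > 2000 nM in this assay, at which 1 of the 2 values shown sits). Compound 2 gives the only proper number shown, 580 nM. Among the measured compounds shown here, the one measured step, an at least 3.4-fold lower number from compound 1 to compound 2 (0.53 log units; beyond the scatter), runs from an ether-bearing chain to an all-carbon chain and is the sole guide here.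

Compound 3 `CC(C)OCCOc1cccc2ccc(N)nc12` returns an ether oxygen into the chain: isopropoxy in place of propyl on a saturated chain carbon, two bonds along the chain from an oxygen on an aromatic ring. This reverses the kind of change seen in the measured step, so the number for compound 3 is expected to move back up from compound 2, by a 2.6-fold higher number from compound 2 to compound 3 (0.41 log units; beyond the scatter), though the branched group may not repeat the full shift. Compound 3 is therefore estimated at 1500 nM, with a range of 500 nM to 5000 nM; a limit-only result is possible.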

Compound 3, half-maximal inhibitory concentration: > 2000 nM
Compound 3 was reported as a limit; the forecaster's own chance of this, stated with the estimate: 35%; at least 1.3-fold (0.12 log units) between middle value and limit.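

In this assay compound 3 gives > 2000 nM, a limit of the assay and not a number, and the second such result in the series: the limit of > 2000 nM in this assay, at which 2 of the 3 values shown sit. Isopropoxy in place of propyl on a saturated chain carbon, two bonds along the chain from an oxygen on an aromatic ring, gives an at least 3.4-fold higher number from compound 2 to compound 3 (0.53 log units; beyond the scatter), so a second ether-bearing chain, this one with a branched end, also falls short of the all-carbon chain of compound 2, the only compound of the three to give a number. The step between the two limits cannot be read, so nothing can be said about the added methyl.

On these data alone, how much binding each ether-bearing chain retains remains unknown. Also open, as far as these compounds go, is how a longer all-carbon chain such as hexyl, or an amine at the chain end, would read at this position.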